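This account rests on a few compounds, and the source may have more. Where it says the series, first, only, none or still open, it means among the compounds named here.

Three compounds of this series share one core and differ only in the group on the saturated ring carbon. Compound 1 `O[C@@H]1Cc2cc(Cl)ccc2N[C@H](c2cccs2)C1` carries an unsubstituted thiophene and gives 115000 nM in an ADME assay on THP-1 cells (Homo sapiens) for cytotoxicity; a higher number here means that more compound is tolerated, a lower number that less compound is tolerated. Compound 2 `Cc1ccc([C@@H]2C[C@H](O)Cc3cc(Cl)ccc3N2)s1` reaches only a limit of this assay, > 2040000 nM, so no number is known for it. Among the measured compounds shown here, compound 3 `Cc1ccsc1[C@@H]1C[C@H](O)Cc2cc(Cl)ccc2N1` gives 181000 nM in this assay; of the two numbers known it holds the upper one, but the step of a 1.6-fold higher number from compound 1 to compound 3 (0.20 log units; within the scatter) stays within the scatter, so compound 1 and compound 3 cannot be told apart. The two steps that involve compound 2 are large, an at least 17-fold higher number from compound 1 to compound 2 (1.24 log units; beyond the scatter) and an at least 11-fold lower number from compound 2 to compound 3 (1.05 log units; beyond the scatter), and both rest on (the limit of > 2040000 nM in this assay, at which 1 of the 3 values shown sits).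

Compound 4 `Cc1ccsc1[C@@H]1C[C@H](O)Cc2cc(F)ccc2N1` differs from compound 3 only in the halogen on the carbocyclic ring: fluoro in place of chloro on an aromatic carbon. For the measured compounds named here, none of the measured steps concerns this position; all three alter the methyl on the thiophene, and the only one between two plain numbers, a 1.6-fold higher number from compound 1 to compound 3 (0.20 log units; within the scatter), lies within the scatter. With no halogen exchange measured, the account expects no step beyond the scatter in this assay, and the estimated step is a 1.0-fold lower number from compound 3 to compound 4 (0.00 log units; within the scatter). Compound 4 is therefore expected to give about 180000 nM in this assay, within a range from 70000 nM to 500000 nM.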

Compound 4, half-maximal cytotoxic concentration: 1810000 nM
Compound 4: middle estimate off by 10-fold (1.00 log units), on the low side; the measured number lies above the stated range.
By their numbers in this assay, from the lowest: compounds 1 and 3 (each within the scatter of the next); then compound 4. At a limit, above all of these: compound 2.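

In this assay, among the compounds shown here, the halogen on the six-membered aromatic ring of carbon only proves to be a place where the number moves: fluoro in place of chloro gives a 10-fold higher number from compound 3 to compound 4 (1.00 log units; beyond the scatter), at a position that none of the earlier steps touched. This is the only step shown beyond the scatter that joins two plain numbers, whereas both earlier steps beyond the scatter rest on a limit: the limit of > 2040000 nM in this assay, at which 1 of the 4 values shown sits. Nothing measured here speaks to what lies behind this step, so the result records the size of the change and gives no reason for it.

The exchange is shown only on the compound carrying the 3-methylthiophen-2-yl group, so it stays open whether it would give a similar step with the unsubstituted thiophene of compound 1 or the 5-methylthiophen-2-yl group of compound 2. Also open, on these data alone, is how a hydrogen, a bromo, a methoxy or a nitrile at this place would compare with chloro and fluoro.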